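Chloro for methyl on the aryl ring of compound 3

A few compounds are considered here, and "the series" means these few. Any claim that something is new, unique, unknown or untested is made for them only; others in the source may bear on it.

Measured so far:
compound 1 `CCOC(=O)c1c(-c2c(Cl)c3ccccc3oc2=O)nn(-c2cccc(Cl)c2)c1C(=O)OCC` — 24000 nM
compound 2 `CCOC(=O)c1c(-c2c(Cl)c3cc(C)ccc3oc2=O)nn(-c2ccccc2)c1C(=O)OCC` — 50000 nM
compound 3 `CCOC(=O)c1c(-c2c(Cl)c3cc(C)ccc3oc2=O)nn(-c2cccc(C)c2)c1C(=O)OCC` — 103000 nM

In a functional assay on DU-145 cells (Homo sapiens) for cytotoxicity, read by MTT assay, with a stated time of 48 h (a higher number here means a weaker inhibitor, a lower number a stronger inhibitor), compound 3 gives the highest number of the three, so it is the weakest inhibitor of this set. Compound 4 `CCOC(=O)c1c(-c2c(Cl)c3cc(C)ccc3oc2=O)nn(-c2cccc(Cl)c2)c1C(=O)OCC` differs from it in one place: chloro in place of methyl on an aromatic carbon. For the measured compounds named here, no measured step covers this exchange directly. Going by the values given here, the only step within the set, a 2.1-fold higher number from compound 2 to compound 3 (0.31 log units; beyond the scatter), concerns the same aromatic carbon and shows that the methyl group raised the number modestly. Compound 1, which carries the chloro group on that ring, gives 24000 nM, a lower number than compound 3 but on a differently substituted core. Compound 4 is therefore expected to sit somewhat lower than compound 3, a change of a 2.6-fold lower number from compound 3 to compound 4 (0.41 log units; beyond the scatter), landing near 40000 nM with a likely range from 15000 nM to 110000 nM.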

Compound 4, half-maximal inhibitory concentration: 156000 nM
For compound 4 the middle estimate is 3.9-fold (0.59 log units) below the measured one; the whole stated range lies below it.
By their numbers in this assay, from the lowest: compound 1; then compound 2; then compounds 3 and 4 (each within the scatter of the next).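

In this assay, the 3-methylphenyl and 3-chlorophenyl compounds are not separated (a 1.5-fold higher number from compound 3 to compound 4 (0.18 log units; within the scatter)), whereas chloro in place of hydrogen on the same aromatic carbon gives a step beyond the scatter (a 3.1-fold higher number from compound 2 to compound 4 (0.49 log units; beyond the scatter)). Methyl in place of hydrogen has no fixed size in this set (a 6.5-fold higher number from compound 1 to compound 4 (0.81 log units; beyond the scatter)): the same change on two cores in this assay, a 2.1-fold higher number (0.31 log units; beyond the scatter) from compound 2 to compound 3 and a 6.5-fold higher number (0.81 log units; beyond the scatter) from compound 1 to compound 4, 3.2-fold (0.50 log units) apart, beyond the scatter of two such steps.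

From the compounds shown here alone, it remains open how an amine or a carboxylic acid at this place on the ring would read in this assay. Whether chloro and methyl also go unseparated on the core of compound 1 is open too.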